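The source may report more compounds than this note shows. Statements on the series, on what has been measured and on what is new or still open speak of the compounds shown alone.

Measured in a functional assay on K562 cells (Homo sapiens) for inhibition, read by thymidine incorporation, with a stated time of 5 h; on this read-out lower numbers stand for stronger inhibition and higher numbers for weaker inhibition:
- compound 1 `C(#Cc1ncnc2c1ncn2Cc1ccccc1)c1ccccc1`: 6 ug/mL
- compound 2 `C(#Cc1nc(-c2ccccc2)nc2c1ncn2Cc1ccccc1)c1ccccc1`: 2.4 ug/mL

Compound 1 has the higher of these two numbers, which makes it the weaker inhibitor of the pair. Going by the values given here, the only measured step is a 2.5-fold lower number from compound 1 to compound 2 (0.40 log units; beyond the scatter), with phenyl in place of hydrogen on an aromatic carbon.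

Compound 3 `C=Cc1ncnc2c1ncn2Cc1ccccc1` has not yet been measured. It keeps the core of compound 1 but carries vinyl in place of 2-phenylethynyl on an aromatic carbon. Compound 2, at 2.4 ug/mL, still carries the 2-phenylethynyl and differs elsewhere, so its step is only a loose guide. Among the compounds with values here, no measured compound alters that group, so the direction remains open and no step beyond the scatter is expected in this assay. The estimated step is no change at the digits printed from compound 1 to compound 3 (within the scatter). For compound 3 the expected value is 6 ug/mL, with an estimated range from 1.5 ug/mL to 25 ug/mL.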

Compound 3, half-maximal inhibitory concentration: 2.2 ug/mL
Compound 3: middle estimate off by 2.7-fold (0.44 log units), on the high side; the measured number falls inside the stated range.
By their numbers in this assay, from the lowest: compounds 3 and 2 (each within the scatter of the next); then compound 1.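

Going by these compounds alone, the first change at this position runs a 2.7-fold lower number from compound 1 to compound 3 (0.44 log units; beyond the scatter) in this assay as the 2-phenylethynyl gives way to vinyl. Inhibition therefore does not depend on the carbon-only aromatic ring or the triple bond of the 2-phenylethynyl, since compound 3 has neither and still gives the lower number. Nothing measured here explains why the change has this effect.

The compounds shown do not tell whether the double bond of vinyl matters, which an ethyl group at this position could test, or how an amine or a carboxylic acid there would compare. They also leave open whether the phenyl that separates compound 2 from compound 1 would lower the number further if placed on compound 3.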